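A few compounds are considered here, and "the series" means these few. Any claim that something is new, unique, unknown or untested is made for them only; others in the source may bear on it.

Measured compounds:
compound 1, `CCCC1=C(N2CC2)C(=O)C(C(COC(N)=O)OC)=C(N2CC2)C1=O`: 4.64
compound 2, `CCOC(COC(N)=O)C1=C(N2CC2)C(=O)C(C)=C(N2CC2)C1=O`: 4.62

Both compounds share the same core and were tested in a functional assay on L1210 cells (Mus musculus), with a stated time of 1 days; on this read-out higher numbers stand for higher potency (the scale is a negative logarithm) and lower numbers for lower potency. In this assay compound 1 gives 4.64, and compound 2 gives 4.62. The two numbers lie within the usual scatter of each other, so nothing separates compound 1 from compound 2 on this read-out; compound 1 simply holds the higher of the two numbers by a margin that means nothing.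

The piece now turns to compound 3, `CCC1=C(N2CC2)C(=O)C(C(COC(N)=O)OC)=C(N2CC2)C1=O`, which has not yet been measured. It differs from compound 1 in one place: hydrogen in place of methyl on a saturated chain carbon, two bonds along the chain from a double-bonded ring carbon. Going by the values given here, no measured pair of compounds shows this kind of change, so there is no observed step to lean on. A propyl chain shortened to an ethyl chain is a small change, and the expectation is for no step beyond the scatter, in either direction.

Compound 3 is therefore expected to give about 4.6, in a range from 4.2 to 5, which means an expected step of a number 0.04 log units lower from compound 1 to compound 3 (within the scatter).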

Compound 3, logarithm of the reciprocal of the active concentration, log(1/C): 4.92
Compound 3: the middle estimate sits 0.32 log units below what was measured, and the stated range covers the measured number.
By their numbers in this assay, from the lowest: compounds 2, 1 and 3 (each within the scatter of the next).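

Cutting the propyl chain to an ethyl chain gives the first observed step at this place on the shared core: in this assay, hydrogen in place of methyl gives a number 0.28 log units higher from compound 1 to compound 3 (within the scatter). The step shows that, on the core of compound 1, this end methyl can go without a change that this read-out can separate from the scatter of repeated measurements. Nothing measured here offers an explanation for the size of this step.

One step between two chain lengths cannot describe the whole position. From the compounds shown here alone, how a longer chain such as butyl, or a chain ending in an amine or a carboxylic acid, would read at this place remains open, as does whether the ethyl chain would read the same way on a different core.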